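A few compounds are considered here, and "the series" means these few. Any claim that something is new, unique, unknown or untested is made for them only; others in the source may bear on it.

Compound 1 `CCOc1ccc2nc(Nc3nc4ccc(F)cc4s3)sc2c1` was tested in a functional assay on THP-1 cells (Homo sapiens) for cytotoxicity, read by MTT assay, with a stated time of 48 h (a lower number here means a stronger inhibitor, a higher number a weaker inhibitor), where compound 1 gives 39000 nM. Compound 2 `Fc1ccc(NC(=S)Nc2nc3ccccc3s2)cc1` and compound 3 `Fc1ccc(NC(=S)Nc2nc3ccc(F)cc3s2)cc1` rest on a different core; the difference between the two cores is not broken down here. In this assay compound 2 gives 26700 nM, and compound 3 gives 34600 nM. The change from compound 3 to compound 2 is hydrogen in place of fluoro on an aromatic carbon, and it made a step of a 1.3-fold lower number from compound 3 to compound 2 (0.11 log units; within the scatter). Compound 4 `CCOc1ccc2nc(Nc3nc4ccccc4s3)sc2c1` has not yet been measured. It differs from compound 1 by hydrogen in place of fluoro on an aromatic carbon, the same change at the same place as before. Compound 4 is expected to give about 33000 nM, with a likely range from 18000 nM to 60000 nM. The expected step is a 1.2-fold lower number from compound 1 to compound 4 (0.07 log units; within the scatter), which rests on the earlier 1.3-fold lower number from compound 3 to compound 2 (0.11 log units; within the scatter) applied to compound 1 and its 39000 nM.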

Compound 4, half-maximal inhibitory concentration: 37100 nM
Beside the measured number, compound 4's estimate is 1.1-fold (0.05 log units) below it, within the range that was stated.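

In this assay, hydrogen in place of fluoro on an aromatic carbon gives a 1.1-fold lower number from compound 1 to compound 4 (0.02 log units; within the scatter), and this step can be set against the same change on the other core: the same change on two cores in this assay, a 1.3-fold lower number (0.11 log units; within the scatter) from compound 3 to compound 2 and a 1.1-fold lower number (0.02 log units; within the scatter) from compound 1 to compound 4, 1.2-fold (0.09 log units) apart, within the scatter of two such steps. The change thus carries from one core to the other in these two pairs, with each step within the scatter and no difference between them. This does not show that the change would stay so small elsewhere in the series: two pairs are all there is, and neither gives a step beyond the scatter that could be tracked across cores.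

The compounds shown leave open whether an amine or a carboxylic acid in place of the fluoro would give a step beyond the scatter. They also leave open how the change would behave on a third core.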